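Methoxy in place of fluoro on the core of compound 1

The source may report more compounds than this note shows. Statements on the series, on what has been measured and on what is new or still open speak of the compounds shown alone.

Measured so far in an assay on IMR-32 cells for displacement of a labelled ligand from corticotropin-releasing factor receptor 1 (Homo sapiens), read by scintillation counting, with a stated time of 2 h; on this read-out lower numbers stand for stronger inhibition and higher numbers for weaker inhibition:
compound 1, `CCc1nc(NC(CC)CC)c(F)nc1-c1ccc(Cl)cc1Cl`, 167 nM
compound 2, `CCc1nc(-c2ccc(Cl)cc2Cl)c(CC)nc1CC(CC)CC`, 68 nM
compound 3, `CCOc1ccc(-c2nc(OC)c(NC(CC)CC)nc2C)c(Cl)c1`, 5.9 nM

Compound 1 stands at the highest of the three numbers. Compound 2 sits below it, a gap beyond the usual scatter, and compound 3 sits far lower still, also beyond the scatter. Compound 3 differs from compound 1 in several places at once, so its value cannot be tied to any single change.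

The next compound, compound 4 `CCc1nc(NC(CC)CC)c(OC)nc1-c1ccc(Cl)cc1Cl`, is not yet measured in this assay. It differs from compound 1 in one place: methoxy in place of fluoro on an aromatic carbon. Compound 3 also carries a methoxy and gives the lowest number of the three, but its other differences leave the contribution of that group open.

A moderate step downward from compound 1 is expected, a 2.8-fold lower number from compound 1 to compound 4 (0.44 log units; beyond the scatter), with wide uncertainty. For compound 4 the estimated value in this assay is 60 nM, expected to lie between 15 nM and 220 nM.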

Compound 4, inhibition constant: 5.9 nM
For compound 4 the middle estimate is 10-fold (1.01 log units) above the measured one; measured number below the stated range.
By their numbers in this assay, from the lowest: compounds 3 and 4 (each within the scatter of the next); then compound 2; then compound 1.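

In this assay, methoxy in place of fluoro on the aromatic carbon para to an ethyl group gives a large step, a 28-fold lower number from compound 1 to compound 4 (1.45 log units; beyond the scatter). Among these compounds, this is the first change that can be read in one place, and it shows that the group at this position, ortho to a (pentan-3-yl)amino group, can by itself move the number well beyond the scatter, which compound 3, with its several differences, could not show. Nothing measured here points to what lies behind the step.

As far as these compounds go, only fluoro and methoxy are seen at this position, so it remains open how an ethoxy, a methyl or a dimethylamino group there would compare. From the compounds shown here alone, whether the exchange of fluoro for methoxy gives a similar step with other groups elsewhere on the core also remains open.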